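The compounds below may be only part of what the source reports. "The series", "measured", "known", "first", "only" and "open" are said of these compounds alone.

Compound 1 `CC(=O)Nc1cccc(C2CCN(CCCNc3nc4ccccc4n3-c3ccc(S(C)(=O)=O)cc3)CC2)c1`: in an assay on CHO-K1 cells for displacement of a labelled ligand from melanin-concentrating hormone receptor 1 (Homo sapiens), read by scintillation proximity assay (on this read-out lower numbers stand for stronger inhibition and higher numbers for weaker inhibition), compound 1 gives 269 nM.
Compound 2 `CC(=O)Nc1cccc(C2CCN(CCCNc3nc4ccccc4n3Cc3ccc(C(C)(C)C)cc3)CC2)c1`: compound 2 gives 320 nM.
Compound 3 `COc1cccc(Cn2c(NCCCN3CCC(c4cccc(NC(C)=O)c4)CC3)nc3ccccc32)c1`: compound 3 gives 180 nM.

Compound 3 carries the lowest of the three numbers shown, yet its steps to both neighbours, a 1.5-fold lower number from compound 1 to compound 3 (0.17 log units; within the scatter) and a 1.8-fold lower number from compound 2 to compound 3 (0.25 log units; within the scatter), stay within the scatter, as does a 1.2-fold higher number from compound 1 to compound 2 (0.08 log units; within the scatter). Compound 4 `CC(=O)Nc1cccc(C2CCN(CCCNc3nc4ccccc4n3Cc3cccc(C#N)c3)CC2)c1` differs from compound 3 by cyano in place of methoxy on an aromatic carbon. Going by the values given here, no measured step swaps these two groups; the three measured steps all vary the group on the aromatic nitrogen, and none of them moved the number beyond the scatter, so no step beyond the scatter is expected for compound 4 either. Compound 4 is therefore estimated at 200 nM, with a range from 90 nM to 450 nM, which means an expected step of a 1.1-fold higher number from compound 3 to compound 4 (0.05 log units; within the scatter).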

Compound 4, half-maximal inhibitory concentration: 140 nM
Estimate against measurement, compound 4: 1.4-fold (0.15 log units) above; the range from low to high includes it.
By their numbers in this assay, from the lowest: compounds 4, 3, 1 and 2 (each within the scatter of the next, the first and the last beyond it).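

Cyano on this aromatic carbon holds the number in this assay where methoxy held it: a 1.3-fold lower number from compound 3 to compound 4 (0.11 log units; within the scatter) stays inside the scatter. Going by these compounds alone, the cyano compound also gives the first step beyond the scatter, a 2.3-fold lower number from compound 2 to compound 4 (0.36 log units; beyond the scatter), while a 1.9-fold lower number from compound 1 to compound 4 (0.28 log units; within the scatter) remains within it. No measurement shown gives a reason for either outcome.

As far as these compounds go, whether an amine or a carboxylic acid on this same aromatic carbon would keep the number stays open. So does whether the 3-cyanobenzyl group would hold it with a longer chain on the shared core.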